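The source may report more compounds than this note shows. Statements on the series, on what has been measured and on what is new or still open speak of the compounds shown alone.

In a functional assay on cells (Neutrophil, Homo sapiens) for inhibition, with a stated time of 10 min (a lower number here means a stronger inhibitor, a higher number a weaker inhibitor), the measured compounds are:
compound 1 `CCOC(=O)c1cnn(C)c1NC(=O)NCc1ccccc1` gives 1.3 nM
compound 2 `CCOC(=O)c1cnn(CC(C)O)c1NC(=O)Nc1cccc(F)c1` gives 0.0007 nM
compound 3 `CCOC(=O)c1cnn(CC(O)CC)c1NC(=O)Nc1cccc(F)c1` gives 0.36 nM

Compound 2 has the lowest number of the three, and its gaps to compound 1 and compound 3 both lie beyond the scatter. The next compound to be measured is compound 4 `CCOC(=O)c1cnn(CC(C)O)c1NC(=O)NC(C)C`, which puts isopropyl in place of 3-fluorophenyl on an amide-type nitrogen and keeps the rest of compound 2.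

Going by the values given here, no measured step covers this exchange. Among the compounds with values here, the only measured step of a 510-fold higher number from compound 2 to compound 3 (2.71 log units; beyond the scatter) changes the hydroxy-bearing chain, not this nitrogen substituent, so it bears only indirectly. It is large and shows how far a single small change can move a number from this low starting point. Compound 1 also lacks the 3-fluorophenyl and gives 1.3 nM but differs from compound 2 in more than one place, so it offers only a rough guide.

A large step towards a weaker inhibitor is therefore expected, with wide uncertainty. The estimated change is a 710-fold higher number from compound 2 to compound 4 (2.85 log units; beyond the scatter) in this assay and lies beyond the scatter. The expected value for compound 4 is 0.5 nM within an estimated range of 0.01 nM to 30 nM in this read-out.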

Compound 4, half-maximal inhibitory concentration: 0.00082 nM
Compound 4: middle estimate off by 610-fold (2.79 log units), on the high side; measured number below the stated range.
By their numbers in this assay, from the lowest: compounds 2 and 4 (each within the scatter of the next); then compound 3; then compound 1.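

In this assay, isopropyl in place of 3-fluorophenyl on the amide-type nitrogen gives a 1.2-fold higher number from compound 2 to compound 4 (0.07 log units; within the scatter), so for this pair a substituent with no ring and no fluorine reads the same as the aromatic one. The step on the hydroxy-bearing chain, a 510-fold higher number from compound 2 to compound 3 (2.71 log units; beyond the scatter), is large by contrast, so among the pairs that differ in one place, the methyl added to that chain moves the number, while this exchange on the nitrogen does not. No measurement of any property bears on this result, and its origin remains unexplained.

Going by these compounds alone, only one pair tests this nitrogen substituent, so it remains open whether isopropyl and 3-fluorophenyl would also read alike on the longer hydroxy-bearing chain of compound 3. Also open, from the compounds shown here alone, is whether a tert-butyl group, a cyclohexyl ring or a chain ending in a carboxylic acid on the same nitrogen would keep the number close to that of compound 4 (0.00082 nM), which would show how broadly this position accepts different groups.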